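Methyl for fluoro on an open-chain hydroxypropyl amide

The compounds below may be only part of what the source reports. "The series", "measured", "known", "first", "only" and "open" are said of these compounds alone.

The measured compounds, all in a functional assay on the whole organism with Mus musculus as the target, in the maximal electroshock model; a lower number here means that less compound is needed, a higher number that more compound is needed for the effect:
compound 1, `COc1ccc(C23CCC(=O)N2CCCO3)cc1`, gives 93.8 mg/kg;
compound 2, `O=C(CCC(=O)c1ccc(F)cc1)NCCCO`, gives > 400 mg/kg;
compound 3, `O=C1CCC2(c3ccc(Cl)cc3)OCCCN12`, gives 58 mg/kg.

For compound 2 this value is a limit of the assay rather than a number, (the limit of > 400 mg/kg in this assay, at which 1 of the 3 values shown sits). So compound 2 stands apart from compound 1 and compound 3, which both have measured doses, and no step from it can be sized.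

Compound 4, `Cc1ccc(C(=O)CCC(=O)NCCCO)cc1`, is not yet measured. It differs from compound 2 by methyl in place of fluoro on an aromatic carbon. Among the measured compounds shown here, the only measured step, a 1.6-fold lower number from compound 1 to compound 3 (0.21 log units; within the scatter), concerns a different exchange on a different core and lay within the scatter; it bears only loosely on the present change. Since compound 2 gives just a limit, the step that the limit leaves unreadable from compound 2 to compound 4 is an estimate with a wide range and may itself end in a limit. Compound 4 is therefore expected at about 500 mg/kg in this assay, between 150 mg/kg and 1500 mg/kg.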

Compound 4, dose for half-maximal effect: > 300 mg/kg
Compound 4: no number, only a limit; the forecaster's own chance of this, stated with the estimate: 70%; the middle value is on the limit's open side.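

In this assay, among the compounds shown here, compound 2 and compound 4 each give only a limit of the assay, so no step between them can be read. The compounds shown leave open whether methyl in place of fluoro on an aromatic carbon changes the dose needed for the effect.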